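Amino for Methoxy in a Resistant Leukaemia Cell Assay

This account rests on a few compounds, and the source may have more. Where it says the series, first, only, none or still open, it means among the compounds named here.

In a functional assay on K-562R cells (Homo sapiens) for cytotoxicity, read by MTT assay, with a stated time of 48 h (on this read-out higher numbers stand for weaker inhibition and lower numbers for stronger inhibition), compound 1 `COc1ccc(-c2c[nH]c(=O)n2-c2cc(OC)c(OC)c(OC)c2)cc1OC` reaches only a limit, > 50000 nM.
In this assay compound 2 `COc1ccc(-c2c[nH]c(=O)n2-c2cc(OC)c(OC)c(OC)c2)cc1N` likewise gives only a limit, > 50000 nM.
In this assay compound 3 `COc1ccc(-c2cn(C(=O)Nc3cc(OC)c(OC)c(OC)c3)c(=O)n2-c2cc(OC)c(OC)c(OC)c2)cc1OC` also gives only a limit, > 50000 nM.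

Compound 1 and compound 2 differ by one change, (amino in place of methoxy on an aromatic carbon). The step that the two limits leave unreadable from compound 1 to compound 2 cannot be sized, because of the limit of > 50000 nM in this assay, at which 3 of the 3 values shown sit. How the core of compound 1 differs from that of compound 3 is not broken down here. Compound 4 `COc1ccc(-c2cn(C(=O)Nc3cc(OC)c(OC)c(OC)c3)c(=O)n2-c2cc(OC)c(OC)c(OC)c2)cc1N` carries the same change relative to compound 3, (amino in place of methoxy on an aromatic carbon), at a place described in identical words. Since compound 3 sits at > 50000 nM, the step that the limit leaves unreadable from compound 3 to compound 4 is expected to stay unreadable in this assay. Compound 4 is therefore estimated at 80000 nM, most likely reported again as a limit rather than a number.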

Compound 4, half-maximal inhibitory concentration: 9400 nM
Compound 4: middle estimate off by 8.5-fold (0.93 log units), on the high side; measured number below the stated range.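

In this assay, amino in place of methoxy on the core of compound 3 gives an at least 5.3-fold lower number from compound 3 to compound 4 (0.72 log units; beyond the scatter), so on this core the change brings a measurable value. This step is a minimum rather than an exact size, and a single pair cannot establish a rule for the series. The same change from compound 1 to compound 2 cannot be read, so these compounds do not show whether the effect carries over between the two cores: the limit of > 50000 nM in this assay, at which 3 of the 4 values shown sit.

Going by these compounds, it remains open whether a dimethylamino group or a hydroxyl group in the same place would act like the amino group. On these data alone, it is also open whether the 3-amino-4-methoxyphenyl group would give a measurable value on any core other than that of compound 4.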